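A few compounds are considered here, and "the series" means these few. Any claim that something is new, unique, unknown or untested is made for them only; others in the source may bear on it.

Measured so far in a functional assay on WHCO1 cells (Homo sapiens) for cytotoxicity, read by MTT assay, with a stated time of 24 h; on this read-out lower numbers stand for stronger inhibition and higher numbers for weaker inhibition:

- compound 1 (`C=CC(O)C1=CC(=O)c2ccccc2C1=O`) gives 4300 nM
- compound 2 (`O=C1C=C([C@H](O)c2ccccc2)C(=O)c2ccccc21`) gives 4300 nM
- compound 3 (`O=C(C1=CC(=O)c2ccccc2C1=O)c1ccc(F)cc1`) gives 74900 nM

Compound 1 stands level with compound 2, and the two share the lowest number of the three. Compound 3 lies well above them, beyond the scatter.

The next compound is compound 4 (`O=C1C=C(C(O)c2cccc(F)c2)C(=O)c2ccccc21`), which differs from compound 1 as follows: 3-fluorophenyl in place of vinyl on a saturated chain carbon bound to a double-bonded ring carbon and an oxygen on a saturated carbon. In words, this is 3-fluorophenyl in place of vinyl on a saturated chain carbon bound to a double-bonded ring carbon and an oxygen on a saturated carbon. Going by the values given here, no measured pair isolates this change. The closest guide is compound 2, which has an aromatic ring without fluorine on that carbon and gives 4300 nM in the same place as compound 1. The expected result in this assay is therefore no step beyond the scatter, with the estimated step being a 1.0-fold higher number from compound 1 to compound 4 (0.02 log units; within the scatter) in this series. The estimate for compound 4 is 4500 nM, with an expected range of 2000 nM to 11000 nM in this assay.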

Compound 4, half-maximal inhibitory concentration: 5500 nM
Compound 4: the middle estimate sits 1.2-fold (0.09 log units) below what was measured, within the range that was stated.
By their numbers in this assay, from the lowest: compounds 1, 2 and 4 (each within the scatter of the next); then compound 3.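

In this assay, 3-fluorophenyl in place of vinyl on a saturated chain carbon bound to a double-bonded ring carbon and an oxygen on a saturated carbon gives a 1.3-fold higher number from compound 1 to compound 4 (0.11 log units; within the scatter). Going by these compounds alone, this is the first step that can be read at this position, and it shows that the vinyl group can give way to a larger, fluorine-bearing aromatic ring with no step beyond the scatter. Nothing on hand gives a reason why the swap leaves the number within the scatter.

The compounds shown leave open how far this tolerance extends, since a single step cannot define the limits of a position. An amine or a carboxylic acid on the aromatic ring, or a longer chain in place of the ring, could still separate from compound 1 in this assay.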